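Swapping an anilide for a nitrile on a shared core

The compounds below may be only part of what the source reports. "The series", "measured", "known", "first", "only" and "open" are said of these compounds alone.

Compound 1 `CCCC(=O)C1=Cc2ccc(OC)cc2OC1c1cc(OC)c(OC)c(OC)c1`: 11700 nM
Compound 2 `CCNC(=O)C1=Cc2ccc(OC)cc2OC1c1cc(OC)c(OC)c(OC)c1`: a limit, > 50000 nM
Compound 3 `COc1ccc2c(c1)OC(c1cc(OC)c(OC)c(OC)c1)C(C(=O)Nc1ccccc1)=C2`: 17500 nM

In a functional assay for inhibition of nuclear factor NF-kappa-B complex (Homo sapiens) (a higher number here means a weaker inhibitor, a lower number a stronger inhibitor), compound 1 gives 11700 nM and compound 3 gives 17500 nM. Compound 3 has the highest number of the two actual numbers, but the gap a 1.5-fold higher number from compound 1 to compound 3 (0.17 log units; within the scatter) lies within the scatter, so the two cannot be ranked. Compound 2 reaches only a limit, (the limit of > 50000 nM in this assay, at which 1 of the 3 values shown sits).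

Compound 4 `COc1ccc2c(c1)OC(c1cc(OC)c(OC)c(OC)c1)C(C#N)=C2` is compound 3 with one change: cyano in place of phenylcarbamoyl on a double-bonded ring carbon. All three measured steps alter the same position. an at least 4.2-fold higher number from compound 1 to compound 2 (0.63 log units; beyond the scatter) and an at least 2.8-fold lower number from compound 2 to compound 3 (0.45 log units; beyond the scatter) show that a small ethylamide is worse than both the propyl ketone and the anilide, while a 1.5-fold higher number from compound 1 to compound 3 (0.17 log units; within the scatter) shows the anilide and ketone are alike. Within the data shown here, no measured step removes the carbonyl altogether, so the nitrile is a leap beyond the known pattern. Cutting the group down even further than in compound 2 is expected to raise the number, a 2.0-fold higher number from compound 3 to compound 4 (0.30 log units; within the scatter). Compound 4 is therefore estimated at 35000 nM, plausibly between 12000 nM and 100000 nM.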

Compound 4, half-maximal inhibitory concentration: 3400 nM
For compound 4 the middle estimate is 10-fold (1.01 log units) above the measured one, and the stated range ends above it.
By their numbers in this assay, from the lowest: compound 4; then compounds 1 and 3 (each within the scatter of the next). At a limit, above all of these: compound 2.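

In this assay this double-bonded ring carbon does not need a carbonyl group: compound 4, with only a nitrile, gives a lower number than the anilide (a 5.1-fold lower number from compound 3 to compound 4 (0.71 log units; beyond the scatter)). It also improves on the propyl ketone (a 3.4-fold lower number from compound 1 to compound 4 (0.54 log units; beyond the scatter)), so compound 4 has the lowest number of the series with neither a carbonyl nor a large group at this position. The widest step (an at least 14-fold lower number from compound 2 to compound 4 (1.16 log units; beyond the scatter)) starts from compound 2, which stands only at a limit: the limit of > 50000 nM in this assay, at which 1 of the 4 values shown sits.

From the compounds shown here alone, how a carboxylic acid, a methyl ester or a plain hydrogen at this position would compare remains open. So does whether replacing a carbonyl group with a nitrile would lower the number on a core carrying different groups in place of the methoxy groups.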